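Shortening the Ester Chain Toward a Methyl Ester

A few compounds are considered here, and "the series" means these few. Any claim that something is new, unique, unknown or untested is made for them only; others in the source may bear on it.

Three esters sharing one core have been tested in a functional assay on HeLa cells (Homo sapiens) for cytotoxicity; on this read-out higher numbers stand for lower toxicity in this test and lower numbers for higher toxicity in this test. Compound 1 `CCCCCCCCOC(=O)C(O)Cn1cnc2c(N)ncnc21` gives 100 ug/mL. Compound 3 `CC(C)CCOC(=O)C(O)Cn1cnc2c(N)ncnc21` gives 400 ug/mL. Compound 2 `CC(C)COC(=O)C(O)Cn1cnc2c(N)ncnc21` reaches only a limit of this test, > 400 ug/mL. Where compound 2 stands is therefore known only as a limit, the one at which one of the three values sits (the limit of > 400 ug/mL in this assay, at which 1 of the 3 values shown sits). Among the measured compounds, an at least 4.0-fold higher number from compound 1 to compound 2 (0.60 log units; beyond the scatter) and a 4.0-fold higher number from compound 1 to compound 3 (0.60 log units; beyond the scatter), while a number no higher from compound 2 to compound 3 (the limit leaves the size open).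

Compound 4 `CCOC(=O)C(O)Cn1cnc2c(N)ncnc21` differs from compound 2 by methyl in place of isopropyl on a saturated chain carbon bound to an oxygen next to a carbonyl group. The step that bears most directly on it is the earlier shortening at the same place, where an at least 4.0-fold higher number from compound 1 to compound 2 (0.60 log units; beyond the scatter); the comparison in which a number no higher from compound 2 to compound 3 (the limit leaves the size open) adds no readable size. For compound 4 the step is expected to read a number no higher from compound 2 to compound 4 (the limit leaves the size open), since compound 2 already sits at its limit > 400 ug/mL. Compound 4 is therefore expected to give 400 ug/mL, between 200 ug/mL and 800 ug/mL.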

Compound 4, minimum cytotoxic concentration: > 400 ug/mL
Compound 4: no number, only a limit (the forecaster's own chance of this, stated with the estimate: 70%); the middle value sits exactly at the limit.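

In this assay compound 4 gives only a limit, > 400 ug/mL. The change from isopropyl to methyl on a saturated chain carbon bound to an oxygen next to a carbonyl group therefore cannot be read in size, and the comparison with compound 3 gives only a direction, a number no lower from compound 3 to compound 4 (the limit leaves the size open), so two of the esters now rest at the limit: the limit of > 400 ug/mL in this assay, at which 2 of the 4 values shown sit. What the new ester does add is that the separation from the longest chain persists with this smaller group, an at least 4.0-fold higher number from compound 1 to compound 4 (0.60 log units; beyond the scatter).

As far as these compounds go, how compound 2 and compound 4 stand against each other remains unknown in this assay, since neither has a number. Also open, from the compounds shown here alone, is how a carboxylic acid or an amide at this place, or a chain longer than that of compound 1, would read in this test.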